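A few compounds are considered here, and "the series" means these few. Any claim that something is new, unique, unknown or untested is made for them only; others in the source may bear on it.

Measured in a functional assay on MCF7 cells (Homo sapiens) for inhibition, read by fluorescence, with a stated time of 72 h; on this read-out lower numbers stand for stronger inhibition and higher numbers for weaker inhibition:
compound 1 `CC(C)n1cnc2c(NC(=N)N)nc(NCCCO)nc21`: 8800 nM
compound 2 `CC[C@H](CO)Nc1nc(NC(=N)N)c2ncn(C(C)C)c2n1`: 4500 nM
compound 3 `CC(C)[C@@H](CO)Nc1nc(NC(=N)N)c2ncn(C(C)C)c2n1`: 2100 nM

Compound 3 has the lowest of the three numbers, and its steps from both other compounds lie beyond the scatter. Compound 4 `CC(C)n1cnc2c(NC(=N)N)nc(OC[C@@H]3CCCN3)nc21` has not yet been measured. It carries (pyrrolidin-2-yl)methoxy in place of (1-(hydroxymethyl)-2-methylpropyl)amino on an aromatic carbon, between two ring nitrogen atoms ((pyrrolidin-2-yl)methoxy in place of (1-(hydroxymethyl)-2-methylpropyl)amino on an aromatic carbon).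

Three measured steps change the group at this place. One is within the scatter (a 2.0-fold lower number from compound 1 to compound 2 (0.29 log units; within the scatter)), and two are modest (a 2.1-fold lower number from compound 2 to compound 3 (0.33 log units; beyond the scatter)) (a 4.2-fold lower number from compound 1 to compound 3 (0.62 log units; beyond the scatter)). None of them replaces the linking nitrogen with oxygen or brings in a ring, so they guide the size only loosely. Going by the largest of them (a 4.2-fold lower number from compound 1 to compound 3 (0.62 log units; beyond the scatter)), only a modest change is expected in this assay, perhaps none beyond the scatter, with a slightly higher number somewhat more likely than a lower one. The expected change is small (a 1.4-fold higher number from compound 3 to compound 4 (0.15 log units; within the scatter)). For compound 4 the estimate is 3000 nM (expected range 800 nM to 11000 nM).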

Compound 4, half-maximal inhibitory concentration: > 100000 nM
Compound 4: a limit, no number (the forecaster's own chance of this, stated with the estimate: 5%); middle value at least 33-fold (1.52 log units) away from the limit.
By their numbers in this assay, from the lowest: compound 3; then compounds 2 and 1 (each within the scatter of the next). At a limit, above all of these: compound 4.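

In this assay, compound 4 stands at a limit and not at a number: (the limit of > 100000 nM in this assay, at which 1 of the 4 values shown sits). The change to (pyrrolidin-2-yl)methoxy is a large step against each of the three amino-linked side chains (an at least 47-fold higher number from compound 3 to compound 4 (1.67 log units; beyond the scatter)) (an at least 22-fold higher number from compound 2 to compound 4 (1.34 log units; beyond the scatter)) (an at least 11-fold higher number from compound 1 to compound 4 (1.05 log units; beyond the scatter)). Compounds 1, 2 and 3 had shown only small or modest differences as the open chain on this aromatic carbon varied, whereas this swap, with the same heavy-atom count on both sides, shows that the position does not accept every group of that size.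

The step changes the linking nitrogen to oxygen and brings in the ring at once, so the compounds shown cannot tell which of the two goes with the loss. A (pyrrolidin-2-yl)methylamino group or an open-chain 3-hydroxypropoxy group on this carbon would separate them.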